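Adding hydroxy to the 3-bromophenyl group of compound 1

A few compounds are considered here, and "the series" means these few. Any claim that something is new, unique, unknown or untested is made for them only; others in the source may bear on it.

Among the measured compounds shown here, in a functional assay on A549 cells (Homo sapiens) for cytotoxicity, read by MTT assay, with a stated time of 72 h (a higher number here means a weaker inhibitor, a lower number a stronger inhibitor), compound 1 `O=C(N/N=C/c1cccc(Br)c1)Nc1cc2c(Nc3ccc(F)c(Cl)c3)ncnc2cc1O[C@H]1CCOC1` gives 10700 nM as the lowest of the three numbers so far. Both others sit higher: compound 2 `N#Cc1ccc(/C=N/NC(=O)Nc2cc3c(Nc4ccc(F)c(Cl)c4)ncnc3cc2O[C@H]2CCOC2)cc1` gives 29100 nM and compound 3 `O=C(N/N=C/c1cccc(Cl)c1Cl)Nc1cc2c(Nc3ccc(F)c(Cl)c3)ncnc2cc1O[C@H]1CCOC1` gives 25000 nM and these two lie within the scatter of each other. Compound 4 `O=C(N/N=C/c1ccc(O)c(Br)c1)Nc1cc2c(Nc3ccc(F)c(Cl)c3)ncnc2cc1O[C@H]1CCOC1` turns 3-bromophenyl into 3-bromo-4-hydroxyphenyl, with hydroxy in place of hydrogen (hydroxy in place of hydrogen on an aromatic carbon). For the measured compounds named here, no measured compound carries this hydroxy. Replacing the whole group gave a 2.7-fold higher number from compound 1 to compound 2 (0.43 log units; beyond the scatter) and a 2.3-fold higher number from compound 1 to compound 3 (0.37 log units; beyond the scatter) as modest steps, so compound 4, which keeps the bromo group, is expected to rise by less, perhaps within the scatter. The expected step is a 1.4-fold higher number from compound 1 to compound 4 (0.15 log units; within the scatter) at most modestly upward. For compound 4 the estimated value is 15000 nM with an expected range from 6000 nM to 35000 nM as its likely span.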

Compound 4, half-maximal inhibitory concentration: 4310 nM
Compound 4: middle estimate off by 3.5-fold (0.54 log units), on the high side, outside the stated range (below it).
By their numbers in this assay, from the lowest: compound 4; then compound 1; then compounds 3 and 2 (each within the scatter of the next).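

In this assay, hydroxy para to a large group and ortho to a bromo group lowers the number, a 2.5-fold lower number from compound 1 to compound 4 (0.39 log units; beyond the scatter), whereas both earlier replacements of the 3-bromophenyl group raised it. The 3-bromo-4-hydroxyphenyl group also compares well with the other two groups, with a 5.8-fold lower number from compound 3 to compound 4 (0.76 log units; beyond the scatter) and a 6.8-fold lower number from compound 2 to compound 4 (0.83 log units; beyond the scatter). Nothing measured here bears on the reason for this shift. Open, going by these compounds, is whether hydroxy gives the same step without the bromo group, and whether a methoxy group or an amine in its place would lower the number as well.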